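A few compounds are considered here, and "the series" means these few. Any claim that something is new, unique, unknown or untested is made for them only; others in the source may bear on it.

Working notes on the series. Two compounds have been run in an ADME assay on HEK-293T cells (Homo sapiens) for cytotoxicity, read by luminescence, with a stated time of 24 h (a higher number here means that more compound is tolerated, a lower number that less compound is tolerated), so far: compound 1 `COc1ccc(Cn2c(C(=O)N3CCNCC3)cc3sccc32)cc1` and compound 2 `COc1ccc(Cn2c(C(=O)N3CCN(Cc4ccccc4)CC3)c(CNC(C)c3ccccc3)c3sccc32)cc1`. In this assay compound 1 gives > 100000 nM, which is a limit of the assay and not a number. In this assay compound 2 gives > 100000 nM, likewise a limit of the assay. Compound 2 therefore stands at the same point as compound 1, which is the limit of > 100000 nM in this assay, at which 2 of the 2 values shown sit, and no ordering between the two can be read from these values.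

Compound 3 `COc1ccc(Cn2c(C(=O)N3CCN(Cc4ccccc4)CC3)c(COCc3ccccc3)c3sccc32)cc1` is the next member to be measured in this assay. It differs from compound 2 by benzyloxy in place of (1-phenylethyl)amino on a saturated chain carbon bound to an aromatic carbon. Among the compounds with values here, no step between measured compounds has been recorded, so there is no measured basis for a direction. The expectation is that the step from compound 2 to compound 3 in this assay is a step that the limit leaves unreadable from compound 2 to compound 3, that is, none beyond the scatter. For compound 3 the estimated value in this assay is 150000 nM, with a range from 60000 nM to 400000 nM.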

Compound 3, half-maximal cytotoxic concentration: > 100000 nM
Compound 3: a limit, no number; the forecaster's own chance of this, stated with the estimate: 75%; the middle value does not contradict the limit.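

No step from compound 2 to compound 3 can be read, since compound 3 also gives only a limit of the assay: the limit of > 100000 nM in this assay, at which 3 of the 3 values shown sit.

The compounds shown leave open whether benzyloxy and (1-phenylethyl)amino differ at all in this assay, and at what concentration compound 1, compound 2 or compound 3 would become cytotoxic.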